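The source may report more compounds than this note shows. Statements on the series, on what has been measured and on what is new or still open speak of the compounds shown alone.

In a functional assay on KBVIN cells (Homo sapiens) for antiproliferative activity, read by sulforhodamine B assay, with a stated time of 3 days (on this read-out lower numbers stand for an effect already at smaller amounts and higher numbers for an effect only at larger amounts of compound), two compounds sharing one core have been measured so far. Compound 1 `CCC1=C(O)c2c(oc(-c3ccc(Br)cc3)cc2=O)C(CC)(CC)C1=O`, with bromo on an aromatic carbon, gives 15.7 uM, and compound 2 `CCC1=C(O)c2c(oc(-c3ccc(CBr)cc3)cc2=O)C(CC)(CC)C1=O`, with bromomethyl in its place, gives 27.9 uM. Among the measured compounds shown here, compound 2 therefore stands within the usual scatter of compound 1, the only other compound with a number.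

The next structure, compound 3 `CCC1=C(O)c2c(oc(-c3ccc(COC)cc3)cc2=O)C(CC)(CC)C1=O`, differs from compound 2 on a saturated chain carbon bound to an aromatic carbon, where methoxy stands in place of bromo: methoxy in place of bromo on a saturated chain carbon bound to an aromatic carbon. The same difference, cut one bond further out, reads bromomethyl to methoxymethyl. For the measured compounds named here, only one measured step is available, and it is a different exchange, so it bears on this one only indirectly. Going by the values given here, with compound 2 reached by a 1.8-fold higher number from compound 1 to compound 2 (0.25 log units; within the scatter), and with no measured compound carrying methoxy, no step beyond the scatter is expected in this assay, and the data favour no direction. The estimated change is a 1.3-fold lower number from compound 2 to compound 3 (0.10 log units; within the scatter). For compound 3 the expected value is 22 uM, within an estimated range of 10 uM to 50 uM.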

Compound 3, concentration for half-maximal effect: 3.4 uM
Estimate against measurement, compound 3: 6.5-fold (0.81 log units) above; the whole stated range lies above it.
By their numbers in this assay, from the lowest: compound 3; then compounds 1 and 2 (each within the scatter of the next).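

In this assay the saturated chain carbon bound to an aromatic carbon proves to be a place where the exchange counts: methoxy in place of bromo there gives an 8.2-fold lower number from compound 2 to compound 3 (0.91 log units; beyond the scatter) and lies beyond the scatter, whereas the earlier step, a 1.8-fold higher number from compound 1 to compound 2 (0.25 log units; within the scatter) for bromomethyl in place of bromo on an aromatic carbon, did not separate its two compounds. The remaining step, a 4.6-fold lower number from compound 1 to compound 3 (0.66 log units; beyond the scatter), also lies beyond the scatter, so compound 3 has the lowest number of the three, with its steps to both others printed as beyond the scatter. No measurement shown here bears on the reason for these steps.

The compounds shown leave open whether the lower number depends on the oxygen itself or on the methoxymethyl group as a whole, since a hydroxymethyl, ethoxymethyl or aminomethyl group does not appear among them. They also leave open whether a longer chain ending in methoxy would read like compound 3 at this place on the shared core.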